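Ether side chain variation on a shared benzoxazolone acid core

The compounds below may be only part of what the source reports. "The series", "measured", "known", "first", "only" and "open" are said of these compounds alone.

Measured so far:
- compound 1, `O=C(O)CCn1c(=O)oc2cc(OCC3CCC3)c(Cl)cc21`: 1260 nM
- compound 2, `O=C(O)CCn1c(=O)oc2cc(OCc3ccccc3)c(Cl)cc21`: 1580 nM

In an assay on HEK293 cells for inhibition of kynurenine 3-monooxygenase (Homo sapiens), read by LC-MS, with a stated time of 20 h (a higher number here means a weaker inhibitor, a lower number a stronger inhibitor), compound 2 gives 1580 nM; compound 1 gives 1260 nM. Within the data shown here, these two lie within the scatter of each other, so compound 2 holds no distinct position among the numbers so far, as the step of a 1.3-fold higher number from compound 1 to compound 2 (0.10 log units; within the scatter) shows.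

Compound 3, `C[C@@H](Oc1cc2oc(=O)n(CCC(=O)O)c2cc1Cl)c1cccnn1`, is not yet measured. It differs from compound 2 as a group of 8 heavy atoms (6 carbon, 2 nitrogen; one six-membered aromatic ring with 2 hetero atoms) in place of a group of 7 heavy atoms (7 carbon; one six-membered aromatic ring of carbon only), on an oxygen on an aromatic ring. Among the measured compounds shown here, only one measured step exists, the one from compound 1 to compound 2 at the same oxygen, and it stayed within the scatter. For the measured compounds named here, no measured step touches a hetero-aromatic replacement or a defined stereocentre on this chain carbon, so the data give no direction for the change.

The expectation for compound 3 is therefore a step of a 1.1-fold lower number from compound 2 to compound 3 (0.02 log units; within the scatter) in this assay, no more than the scatter, with 1500 nM estimated within the range 500 nM to 4500 nM.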

Compound 3, half-maximal inhibitory concentration: 631 nM
Compound 3: middle estimate off by 2.4-fold (0.38 log units), on the high side; the range from low to high includes it.
By their numbers in this assay, from the lowest: compounds 3, 1 and 2 (each within the scatter of the next, the first and the last beyond it).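

Among these compounds, on an oxygen on an aromatic ring, the side chain now yields a separation beyond the scatter: replacing benzyl with the group carrying a six-membered aromatic ring with 2 hetero atoms and 1 defined stereocentre gives a 2.5-fold lower number from compound 2 to compound 3 (0.40 log units; beyond the scatter) in this assay as the first such step. Against the cyclobutyl-bearing compound 1, the same group gives a 2.0-fold lower number from compound 1 to compound 3 (0.30 log units; within the scatter) and is not set apart, so the distinct separation holds against benzyl only. Nothing on hand bears on the origin of the step.

On these data alone, the entering group differs from benzyl in both its ring and its chain carbon, so the share of each stays open. A pyridine ring on the same branched carbon, the opposite stereocentre and an unbranched methylene link would separate these contributions.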